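Replacing an aromatic group with acetamido on a shared core

The source may report more compounds than this note shows. Statements on the series, on what has been measured and on what is new or still open speak of the compounds shown alone.

compound 1 `O=C1Nc2ccc(S(=O)(=O)N3CCOCC3)cc2/C1=N/c1ccc(Br)cc1`: 11900 nM
compound 2 `O=C1Nc2ccc(S(=O)(=O)N3CCOCC3)cc2/C1=N/c1ccc(O)cc1`: 10400 nM
compound 3 `O=C1Nc2ccc(S(=O)(=O)N3CCOCC3)cc2/C1=N/c1cccc(C(F)(F)F)c1`: 14300 nM

In a functional assay on HepG2 cells (Homo sapiens) for cytotoxicity, read by sulforhodamine B assay, with a stated time of 24 h (a lower number here means a stronger inhibitor, a higher number a weaker inhibitor), compound 3 gives 14300 nM. That number sits level with the other two, as the measured steps are a 1.2-fold higher number from compound 1 to compound 3 (0.08 log units; within the scatter) and a 1.4-fold higher number from compound 2 to compound 3 (0.14 log units; within the scatter). Repeat measurements of a single compound can differ by as much, so these three cannot be ranked.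

Compound 4 `CC(=O)N/N=C1\C(=O)Nc2ccc(S(=O)(=O)N3CCOCC3)cc21`, not yet measured, keeps the core of compound 3 but carries acetamido in place of 3-(trifluoromethyl)phenyl on a double-bonded nitrogen. The two steps above changed the group at this same place, while the remaining step, a 1.1-fold lower number from compound 1 to compound 2 (0.06 log units; within the scatter), put hydroxy in place of bromo on an aromatic carbon. None of these steps removes the aromatic ring from that nitrogen, so the new change goes further than anything measured so far.

Exchanging the group on that nitrogen gave only a 1.4-fold higher number from compound 2 to compound 3 (0.14 log units; within the scatter), so no step beyond the scatter is expected in this assay. The expected step is a 1.1-fold higher number from compound 3 to compound 4 (0.05 log units; within the scatter). The range stays wide, as every measured compound has an aromatic ring on that nitrogen. For compound 4 the estimated value is 16000 nM, with an expected range from 7000 nM to 40000 nM.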

Compound 4, half-maximal inhibitory concentration: 27500 nM
Beside the measured number, compound 4's estimate is 1.7-fold (0.24 log units) below it; low and high end bracket the measured number.
By their numbers in this assay, from the lowest: compounds 2, 1, 3 and 4 (each within the scatter of the next, the first and the last beyond it).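

In this assay the earlier changes on the double-bonded nitrogen only swapped one aromatic ring for another, and none of them moved the number beyond the scatter. Among these compounds, removing the ring and putting acetamido there is the first change at this place to do so: acetamido in place of 4-hydroxyphenyl gives a 2.6-fold higher number from compound 2 to compound 4 (0.42 log units; beyond the scatter) and acetamido in place of 4-bromophenyl gives a 2.3-fold higher number from compound 1 to compound 4 (0.36 log units; beyond the scatter), both modest, while acetamido in place of 3-(trifluoromethyl)phenyl gives a 1.9-fold higher number from compound 3 to compound 4 (0.28 log units; within the scatter) and so cannot be told apart from repeat measurements. This place on the shared core can therefore affect the number in this cell assay, at least for two of the three comparisons, but no measurement here explains the shift.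

The loss of the aromatic ring and the arrival of acetamido come in a single change, so the compounds shown cannot say which of the two matters. A cyclohexyl ring on that nitrogen would keep a ring without aromatic character, and a longer chain such as butanamido would keep the amide while extending it, so each would test one half of that change.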